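Removing one methyl from compound 2

The source may hold more compounds than are shown below. What is called first, only, known or untested is meant among the compounds shown, and "the series" means these compounds.

Compound 1 `CCCCCCN(CCCCCC)C(=O)[C@H](CC)N1CCCC1=O` gives 560 umol/kg
Compound 2 `CC[C@@H](C(=O)N(C)OC)N1CCCC1=O` gives 1000 umol/kg

In a functional assay on the whole organism with Mus musculus as the target (on this read-out higher numbers stand for an effect only at larger amounts of compound and lower numbers for an effect already at smaller amounts), compound 2 stands level with compound 1: their two values lie within the usual scatter of repeated measurements, so neither can be ranked over the other. The next molecule, compound 3 `CC[C@@H](C(=O)NOC)N1CCCC1=O`, has not been measured yet. It comes from compound 2 through one small edit (hydrogen in place of methyl on an amide-type nitrogen), namely hydrogen in place of methyl on an amide-type nitrogen. Going by the values given here, no measured pair shows this edit on its own, so the data offer no direct guide. There is one indirect hint: compound 1 at 560 umol/kg and compound 2 at 1000 umol/kg carry quite different groups on the amide-type nitrogen, yet they do not separate beyond the scatter. A large step from so small an edit therefore seems unlikely. The expected change is a 1.7-fold lower number from compound 2 to compound 3 (0.22 log units; within the scatter), which means no step beyond the scatter. For compound 3 the estimated value is 600 umol/kg, with an expected range from 150 umol/kg to 1800 umol/kg in this whole-animal test.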

Compound 3, dose for half-maximal effect: 1000 umol/kg
Estimate against measurement, compound 3: 1.7-fold (0.22 log units) below, within the range that was stated.
By their numbers in this assay, from the lowest: compounds 1, 2 and 3 (each within the scatter of the next).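

In this assay, hydrogen in place of methyl on the amide-type nitrogen gives no change at the digits printed from compound 2 to compound 3 (within the scatter). Going by these compounds alone, this is the first direct reading of this edit, since the earlier compounds offered no pair that differed by this change alone and only hinted at what it might do. It shows that, with the methoxy group kept on the same nitrogen, methyl can leave this position without a step beyond the scatter in this whole-animal test, though this rests on a single pair and one read-out, and nothing available here bears on why the number holds, so the result stands as an observation without an explanation.

What the compounds shown leave open is how far this tolerance reaches: an ethyl group or a longer chain in place of that methyl could behave differently from the two small cases seen here. Equally open, as far as these compounds go, is the role of the methoxy group itself, since a hydroxy group or a plain amine-derived amide with no oxygen on that nitrogen would test whether the methoxy group matters at all.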